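The source may report more compounds than this note shows. Statements on the series, on what has been measured and on what is new or still open speak of the compounds shown alone.

Compound 1 `COc1ccc(CN(C(=O)CSc2nc3ccccc3s2)c2cc(OC)c(OC)c(OC)c2)cc1O`: in a functional assay on PC-3 cells (Homo sapiens) for antiproliferative activity, read by MTT assay, with a stated time of 48 h (a higher number here means a weaker inhibitor, a lower number a stronger inhibitor), compound 1 gives 2110 nM.
Compound 2 `COc1cc(CN(C(=O)CSc2nc3ccccc3s2)c2cc(OC)c(OC)c(OC)c2)cc(OC)c1OC`: in this assay compound 2 reaches only a limit of the assay, > 80000 nM.

Among the compounds with values here, compound 1 therefore stands as the single real number in this set, the other entry being a limit (the limit of > 80000 nM in this assay, at which 1 of the 2 values shown sits). Within the data shown here, the one measured step is an at least 37-fold higher number from compound 1 to compound 2 (1.57 log units; beyond the scatter), a large loss of potency when the 3-hydroxy-4-methoxyphenyl is exchanged. Compound 3 `COc1cc(N(Cc2ccc(Br)cc2)C(=O)CSc2nc3ccccc3s2)cc(OC)c1OC` carries a different exchange at the same place: 4-bromophenyl in place of 3-hydroxy-4-methoxyphenyl on a saturated chain carbon bound to an amide-type nitrogen. Among the measured compounds shown here, only that measured step bears on this change, and it points toward a weaker inhibitor once the 3-hydroxy-4-methoxyphenyl is gone. A large step in the same direction is therefore expected, a 14-fold higher number from compound 1 to compound 3 (1.15 log units; beyond the scatter), though whether the limit is reached again is uncertain. Compound 3 is estimated at 30000 nM, in a range from 5000 nM to 100000 nM.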

Compound 3, half-maximal inhibitory concentration: > 80000 nM
Compound 3: a limit, no number (the forecaster's own chance of this, stated with the estimate: 35%); at least 2.6-fold (0.42 log units) between middle value and limit.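

Exchanging the 3-hydroxy-4-methoxyphenyl for 4-bromophenyl in this assay gives an at least 37-fold higher number from compound 1 to compound 3 (1.57 log units; beyond the scatter), so the loss seen with 3,4,5-trimethoxyphenyl is not tied to that one replacement. Among the compounds shown, only compound 1, with its 3-hydroxy-4-methoxyphenyl, gives a real number, and two quite different groups at this place both end in a limit. The step from compound 2 to compound 3 cannot be read, because both values are limits: the limit of > 80000 nM in this assay, at which 2 of the 3 values shown sit.

On these data alone, what stays open is whether the hydroxy group, the methoxy group or the two together account for the activity of compound 1. A 3-hydroxyphenyl or a 4-methoxyphenyl at this place would begin to separate them, and a 3-aminophenyl would test whether another group can stand in for the hydroxy.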